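This account rests on a few compounds, and the source may have more. Where it says the series, first, only, none or still open, it means among the compounds named here.

Measured so far:
Compound 1, `c1ccc(-c2cc(-c3ccccn3)nc(-c3ccccn3)c2)cc1`: 0.0014 ug/mL
Compound 2, `c1ccc(-c2cc(-c3cccs3)cc(-c3ccncc3)n2)nc1`: 0.52 ug/mL

Both numbers come from a functional assay on HT-29 cells (Homo sapiens) for antiproliferative activity; a higher number here means a weaker inhibitor of growth, a lower number a stronger inhibitor of growth. Compound 2 gives 0.52 ug/mL, the higher of the two numbers, while compound 1 gives 0.0014 ug/mL, a gap well beyond the scatter. Compound 3, `c1ccc(-c2cc(-c3cccs3)cc(-c3ccccn3)n2)nc1`, has not yet been measured. It differs from compound 2 in one place: pyridin-2-yl in place of pyridin-4-yl on an aromatic carbon. Compound 3 thus carries two pyridin-2-yl groups, as compound 1 does. A large downward step is expected, because compound 1 gives 0.0014 ug/mL with that arrangement. Compound 3 is therefore estimated at 0.005 ug/mL, within 0.001 ug/mL to 0.03 ug/mL, an expected step of a 100-fold lower number from compound 2 to compound 3 (2.02 log units; beyond the scatter).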

Compound 3, concentration for 50% growth inhibition: 0.0018 ug/mL
The estimate for compound 3 lay 2.8-fold (0.44 log units) above the measured number; measured number inside the range.
By their numbers in this assay, from the lowest: compounds 1 and 3 (each within the scatter of the next); then compound 2.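

In this assay, pyridin-2-yl in place of pyridin-4-yl, the same atoms joined differently, brings a 290-fold lower number from compound 2 to compound 3 (2.46 log units; beyond the scatter), so where this ring's nitrogen sits matters greatly at this position. Thiophen-2-yl in place of phenyl brings a 1.3-fold higher number from compound 1 to compound 3 (0.11 log units; within the scatter), so with two pyridin-2-yl groups present, this exchange makes no readable difference. No measurement here explains why the nitrogen's location matters so much.

The compounds shown leave open how pyridin-3-yl would behave at this position, and whether furan-2-yl or an amine could replace thiophen-2-yl without losing activity.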